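Stripping a Second Methoxy Group from a Thiadiazole Scaffold

The source may hold more compounds than are shown below. What is called first, only, known or untested is meant among the compounds shown, and "the series" means these compounds.

Measured compounds:
- Compound 1, `COc1ccc(-c2cc3[nH]nc(-c4cc(OC)c(OC)c(OC)c4)n3n2)cc1`: 26400 nM
- Compound 2, `COc1ccc(-c2nn3c(-c4ccc(OC)c(OC)c4OC)nnc3s2)cc1N`: 82 nM
- Compound 3, `COc1ccc(-c2nn3c(-c4ccc(OC)c(OC)c4)nnc3s2)cc1N`: 522 nM

In a functional assay on A549 cells (Homo sapiens) for antiproliferative activity, read by MTT assay, with a stated time of 72 h (a lower number here means a stronger inhibitor, a higher number a weaker inhibitor), compound 3 gives 522 nM, the second highest of the three numbers. Its nearest neighbour is compound 2, whose value in this assay is 82 nM; compound 1, built on a different core, gives 26400 nM, far weaker than either of the others.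

The unmeasured compound 4, `COc1ccc(-c2nnc3sc(-c4ccc(OC)c(N)c4)nn23)cc1`, differs from compound 3 by a single change: hydrogen in place of methoxy on an aromatic carbon.

For the measured compounds named here, one measured step bears directly on this: the move from compound 2 to compound 3 removed a methoxy group from the same ring, and the number rose, a 6.4-fold higher number from compound 2 to compound 3 (0.80 log units; beyond the scatter). Compound 4 removes a further methoxy group from that ring. The expectation is therefore that the number rises again, by a step of similar size, a 3.8-fold higher number from compound 3 to compound 4 (0.58 log units; beyond the scatter), though it is uncertain whether a second removal costs as much as the first.

For compound 4 in this assay the estimate is 2000 nM, with a likely range from 700 nM to 6000 nM.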

Compound 4, half-maximal inhibitory concentration: 14900 nM
For compound 4 the middle estimate is 7.5-fold (0.87 log units) below the measured one; measured number above the stated range.
By their numbers in this assay, from the lowest: compound 2; then compound 3; then compounds 4 and 1 (each within the scatter of the next).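

In this assay, removing the methoxy group that sits ortho to a methoxy group and meta to a large group gives a 29-fold higher number from compound 3 to compound 4 (1.46 log units; beyond the scatter) as a large step, bigger than the modest 6.4-fold higher number from compound 2 to compound 3 (0.80 log units; beyond the scatter) seen for the earlier removal from the same ring. The two methoxy groups therefore do not count equally: losing this one, from a ring that has already lost another, costs far more than the first loss did. Nothing measured here explains why the second step is so much larger than the first.

At this carbon the compounds shown carry only a methoxy group or a hydrogen, so it remains open whether the methoxy group itself matters or whether a hydroxyl group, a fluorine atom or a longer ethoxy chain could take its place. It is also open what this same removal would cost with the other methoxy group of compound 2 still on the ring, since each step shown was taken from a different starting compound.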